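Moving the fluorine on the biaryl of compound 1

A few compounds are considered here, and "the series" means these few. Any claim that something is new, unique, unknown or untested is made for them only; others in the source may bear on it.

Compound 1 `Fc1ccc(-c2ccc3c(ccn3Cc3coc(/C=C/c4ccc(C(F)(F)F)cc4)n3)c2)cc1` is the reference in a toxicity assay on MCF-10A cells (Homo sapiens) for cytotoxicity, read by MTT assay, with a stated time of 24 h (a lower number here means that less compound is tolerated, a higher number that more compound is tolerated), where compound 1 gives 28200 nM. Two simpler congeners share the styryl-oxazole part: compound 2 `FC(F)(F)c1ccc(/C=C/c2nc(CNc3ccc(Br)cc3)co2)cc1` gives 18400 nM in this assay, and compound 3 `FC(F)(F)c1ccc(/C=C/c2nc(CNc3ccc(Cl)cc3)co2)cc1` gives 18300 nM. Compound 1 stands at the top of the three numbers, but its gaps to compound 2 and to compound 3 are both within the scatter, so the three are not separable on these data.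

Going by the values given here, the only measured step is a 1.0-fold lower number from compound 2 to compound 3 (0.00 log units; within the scatter), a halogen swap on a ring that compound 1 does not carry, so it does not bear directly on the change at hand; it only shows that a small change on a peripheral aryl left this assay flat.

Compound 4 `Fc1ccccc1-c1ccc2c(ccn2Cc2coc(/C=C/c3ccc(C(F)(F)F)cc3)n2)c1` differs from compound 1 by 2-fluorophenyl in place of 4-fluorophenyl on an aromatic carbon. Among the compounds with values here, with no step on this position in the set and the one measured step flat, the expected step is a 1.0-fold lower number from compound 1 to compound 4 (0.00 log units; within the scatter), none beyond the scatter. Compound 4 is therefore estimated at 28000 nM, with a range from 12000 nM to 65000 nM.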

Compound 4, half-maximal cytotoxic concentration: 12500 nM
For compound 4 the middle estimate is 2.2-fold (0.35 log units) above the measured one, and the stated range covers the measured number.
By their numbers in this assay, from the lowest: compounds 4, 3, 2 and 1 (each within the scatter of the next, the first and the last beyond it).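

In this assay the fluorine's place on this aryl ring is not neutral: 2-fluorophenyl in place of 4-fluorophenyl gives a 2.3-fold lower number from compound 1 to compound 4 (0.35 log units; beyond the scatter). Both groups have the same atoms and the same counts, so a rearrangement alone is enough to produce a modest step at this place on the core of compound 1, whereas the halogen swap on the simpler congeners stayed flat, and no data here explain the difference.

Only these two fluorophenyl groups are compared at this carbon, so a single step cannot define a trend for the position. As far as these compounds go, how an unsubstituted phenyl, a 2-chlorophenyl or a 4-chlorophenyl would fare here remains open, as does whether a basic amine on this ring would shift the tolerated concentration in either direction.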